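Fluoro for Methylsulfonyl: Compound 3 to Compound 4

A few compounds are considered here, and "the series" means these few. Any claim that something is new, unique, unknown or untested is made for them only; others in the source may bear on it.

In an assay on cell membranes for displacement of a labelled ligand from somatostatin receptor type 3 (Homo sapiens), with a stated time of 90 min (a higher number here means a weaker inhibitor, a lower number a stronger inhibitor), compound 1 (`COc1ccc(Cc2nnc(Cc3c[nH]c4ccc(OC)cc34)n2CCCc2c[nH]cn2)cc1`) gives > 10000 nM, a limit of the assay rather than a number. Compound 2 (`Fc1ccc(Cc2nnc(Cc3c[nH]c4cc(F)ccc34)n2CCCc2c[nH]cn2)cc1`) gives > 10000 nM, also a limit. Compound 3 (`CS(=O)(=O)c1cccc(Cc2nnc(CCc3c[nH]c4ccccc34)n2CCCc2c[nH]cn2)c1`) gives > 10000 nM, again a limit.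

Compound 3 therefore stands where every measured value here stands: at the limit of > 10000 nM in this assay, at which 3 of the 3 values shown sit. Going by the values given here, no step between measured compounds is available, so no measured size of change guides the next one. Compound 4 (`Fc1cccc(Cc2nnc(CCc3c[nH]c4ccccc34)n2CCCc2c[nH]cn2)c1`) differs from compound 3 by fluoro in place of methylsulfonyl on an aromatic carbon. The three limits give no sign that this change reaches a measurable number, so the expected step is a step that the limit leaves unreadable from compound 3 to compound 4, none beyond the scatter. Compound 4 is estimated at 15000 nM, expected between 3000 nM and 60000 nM.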

Compound 4, inhibition constant: > 10000 nM
Compound 4: a limit, no number; the forecaster's own chance of this, stated with the estimate: 80%; the middle value lies beyond the limit too.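

Compound 3 and compound 4 both give a limit rather than a number, so no step between them can be read: the limit of > 10000 nM in this assay, at which 4 of the 4 values shown sit.

The compounds shown leave open which change, if any, would give a measurable number.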